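The source may hold more compounds than are shown below. What is called first, only, known or untested is meant among the compounds shown, and "the series" means these compounds.

Measured so far in a functional assay on H9c2 cells (Mus musculus) for cytotoxicity against H9c2 (Rattus norvegicus), read by MTT assay, with a stated time of 24 h; on this read-out lower numbers stand for an effect already at smaller amounts and higher numbers for an effect only at larger amounts of compound: compound 1 `COc1ccc(Cc2coc3cc(O)cc(O)c3c2=O)cc1` gives > 100000 nM; compound 2 `COc1ccc(Cc2coc3cc(O)ccc3c2=O)cc1` gives 32100 nM.

For compound 1 this value is a limit of the assay, not a number (the limit of > 100000 nM in this assay, at which 1 of the 2 values shown sits); its standing is therefore known only as a range. Going by the values given here, the one measured step, an at least 3.1-fold lower number from compound 1 to compound 2 (0.49 log units; beyond the scatter), concerns a different change of the shared core. Compound 3 `COc1ccc(Cc2coc3cc(OCC=C(C)C)cc(O)c3c2=O)cc1` differs from compound 1 by 3-methylbut-2-en-1-yl in place of hydrogen on an oxygen on an aromatic ring. Among the compounds with values here, no measured step covers this change, so its direction rests on nothing firm beyond the observation that the single alteration measured lowered the number. A lower number is expected for compound 3, an at least 2.0-fold lower number from compound 1 to compound 3 (0.30 log units; that floor lies within the scatter), giving an estimate of 50000 nM within 15000 nM to 150000 nM.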

Compound 3, half-maximal effective concentration: > 100000 nM
Compound 3 was reported as a limit; the forecaster's own chance of this, stated with the estimate: 35%; at least 2.0-fold (0.30 log units) between middle value and limit.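

Compound 1 and compound 3 both stand as limits rather than numbers, so no step between them can be read: the limit of > 100000 nM in this assay, at which 2 of the 3 values shown sit.

From the compounds shown here alone, whether 3-methylbut-2-en-1-yl in place of hydrogen on that oxygen shifts the read-out at all remains open.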